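Adding a Chlorine to an Anilide Sulfonamide Aortic Antagonist

This account rests on a few compounds, and the source may have more. Where it says the series, first, only, none or still open, it means among the compounds named here.

Compound 1, with the structure `CC(C)c1ccc2c(CCCCCS(=O)(=O)Nc3ccccc3)cc(C(=O)O)c-2cc1`, was tested in a functional assay on thoracic aorta for antagonist activity at thromboxane A2 receptor (Rattus norvegicus) (on this read-out higher numbers stand for weaker inhibition and lower numbers for stronger inhibition), where compound 1 gives 1500 nM. Among the two compounds with numbers, compound 1 has the lowest figure, but its nearest neighbour, compound 2, with the structure `CC(C)c1ccc2c(CCCCS(=O)(=O)Nc3ccc(Cl)cc3)cc(C(=O)O)c-2cc1`, gives 2600 nM in this assay, and the two values lie within the scatter of each other, so no order between them can be read.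

Compound 3, with the structure `CC(C)c1ccc2c(CCCCCS(=O)(=O)Nc3ccc(Cl)cc3)cc(C(=O)O)c-2cc1`, has not been measured in this assay. It differs from compound 1 by chloro in place of hydrogen on an aromatic carbon, the chloro entering on an aromatic carbon of a six-membered aromatic ring of carbon only, para to a large group. For the measured compounds named here, no measured pair shows this change on its own, so the size of the step is unknown. The closest hint is compound 2, which carries the same chloro on a shorter chain and whose value sits within the scatter of compound 1.

Compound 3 is therefore expected to stay close to compound 1, with a step of a 1.2-fold higher number from compound 1 to compound 3 (0.08 log units; within the scatter) not beyond the scatter. The estimate for compound 3 is 1800 nM, between 700 nM and 4500 nM.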

Compound 3, half-maximal inhibitory concentration: 1700 nM
For compound 3 the middle estimate is 1.1-fold (0.02 log units) above the measured one; the range from low to high includes it.
By their numbers in this assay, from the lowest: compounds 1, 3 and 2 (each within the scatter of the next).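

In this assay, the change from phenyl to 4-chlorophenyl, now seen on its own, gives a 1.1-fold higher number from compound 1 to compound 3 (0.05 log units; within the scatter) and so stays within the scatter: at this aromatic carbon, para to a large group, chloro in place of hydrogen leaves no readable mark on the number. Compound 2 could offer only a hint about this change, as it carries the same chloro on a shorter chain; compound 3 at 1700 nM and compound 2 at 2600 nM also lie within the scatter of each other, so the two chloro compounds show no order. No measured evidence is available to explain why the chloro makes so little difference here.

The compounds shown leave open whether a group unlike chloro at this same place, such as an amine, a methoxy group or a carboxylic acid, would move the number beyond the scatter. They also leave open whether a longer chain, or a second chloro on the same ring, would do so.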